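Swapping the amide substituent: expected exposure of compound 3

This account rests on a few compounds, and the source may have more. Where it says the series, first, only, none or still open, it means among the compounds named here.

Compound 1, `NCc1cc(Oc2cccc(C(=O)N3CC[C@@H](N)C3)c2)nc(C(F)(F)F)c1`: 1230 nM in an ADME assay on the whole organism (lung, Mus musculus) for pharmacokinetics, read by LC-MS, at a dose of 30 mg/kg by the oral route; a higher number here means more compound in the circulation at the dose given, a lower number less compound in the circulation
Compound 2, `NCc1cc(Oc2cccc(C(=O)NCCn3cnnn3)c2)nc(C(F)(F)F)c1`: 3460 nM

For the measured compounds named here, compound 2 stands at the higher of the two numbers measured so far in this assay, and its nearest neighbour is compound 1, the step being a 2.8-fold higher number from compound 1 to compound 2 (0.45 log units; beyond the scatter). Compound 3, `NCc1cc(Oc2cccc(C(=O)N3CC[C@@H](O)C3)c2)nc(C(F)(F)F)c1`, has not yet been measured. It differs from compound 2 by a group of 6 heavy atoms (4 carbon, 1 nitrogen, 1 oxygen; one five-membered non-aromatic ring with 1 hetero atom) in place of a group of 8 heavy atoms (3 carbon, 5 nitrogen; one five-membered aromatic ring with 4 hetero atoms), on a carbonyl carbon. Going by the values given here, the only step that bears on this change is the one from compound 1 to compound 2, which runs in the opposite direction and in which a five-membered non-aromatic ring with one hetero atom gave the lower number. The group entering in compound 3 is not the same as that in compound 1, so the size of the return is uncertain. Still, a modest drop is expected, with a 2.3-fold lower number from compound 2 to compound 3 (0.36 log units; beyond the scatter). Compound 3 is therefore estimated at 1500 nM, within 600 nM to 4000 nM.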

Compound 3, maximal plasma concentration: 9130 nM
Compound 3: middle estimate off by 6.1-fold (0.78 log units), on the low side, and the stated range ends below it.
By their numbers in this assay, from the lowest: compound 1; then compound 2; then compound 3.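

On the carbonyl carbon, a five-membered non-aromatic ring does not in itself give the lower number in this assay: with 3-hydroxypyrrolidin-1-yl in place of the group bearing the five-membered aromatic ring with 4 hetero atoms, the direction suggested by compound 1 is reversed (a 2.6-fold higher number from compound 2 to compound 3 (0.42 log units; beyond the scatter)). The comparison within the saturated ring shows that its single substituent carries much of the difference, with hydroxy in place of amino on a saturated ring carbon (a 7.4-fold higher number from compound 1 to compound 3 (0.87 log units; beyond the scatter)). Nothing available accounts for either step.

On these data alone, it remains open whether a methoxy group, a carboxylic acid or a hydroxymethyl group on that ring carbon would keep the number as high as hydroxy does. The compounds shown also leave open what the opposite configuration at the hydroxy-bearing stereocentre would give.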